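The source may hold more compounds than are shown below. What is called first, only, known or untested is meant among the compounds shown, and "the series" means these compounds.

Compound 2 `C=C1[C@@H](OC(C)=O)C[C@@H]2[C@](C)(COC=O)[C@H](OC(C)=O)CC[C@@]2(C)[C@@H]1C[C@@H](Nc1ccc(C(=O)O)cc1)C1=CCOC1=O` gives 41700 nM in a functional assay on MCF7 cells (Homo sapiens) for cytotoxicity, read by sulforhodamine B assay (a higher number here means a weaker inhibitor, a lower number a stronger inhibitor), and stands highest of the two numbers measured, though compound 1 `C=C1[C@@H](OC(C)=O)C[C@@H]2[C@](C)(COC=O)[C@H](OC(C)=O)CC[C@@]2(C)[C@@H]1C[C@@H](Nc1ccc(OC)cc1)C1=CCOC1=O`, which gives 24200 nM, lies within the scatter of it. Compound 3 `C=C1[C@@H](OC(C)=O)C[C@@H]2[C@](C)(COC=O)[C@H](OC(C)=O)CC[C@@]2(C)[C@@H]1C[C@@H](Nc1ccccc1F)C1=CCOC1=O` is not yet measured. It differs from compound 2 by 2-fluorophenyl in place of 4-carboxyphenyl on an amine nitrogen. Among the compounds with values here, the only step measured, a 1.7-fold higher number from compound 1 to compound 2 (0.24 log units; within the scatter), changed a group at the same place without a shift beyond the scatter, so no basis exists for expecting a large step. Compound 3 is therefore expected to give 25000 nM, within 8000 nM to 75000 nM, a step of a 1.7-fold lower number from compound 2 to compound 3 (0.22 log units; within the scatter).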

Compound 3, half-maximal inhibitory concentration: 16400 nM
Estimate against measurement, compound 3: 1.5-fold (0.18 log units) above; low and high end bracket the measured number.
By their numbers in this assay, from the lowest: compounds 3, 1 and 2 (each within the scatter of the next, the first and the last beyond it).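

At this amine nitrogen, the choice of aryl group can shift the number in this assay beyond the scatter: 2-fluorophenyl in place of 4-carboxyphenyl gives a 2.5-fold lower number from compound 2 to compound 3 (0.41 log units; beyond the scatter) and is the first step shown to do so, though only modestly. In place of 4-methoxyphenyl, the same group gives a 1.5-fold lower number from compound 1 to compound 3 (0.17 log units; within the scatter) and leaves the number within the scatter.

With the carboxylic acid leaving and the fluorine entering in one step, the compounds shown leave open whether a plain phenyl or a benzyl group on this nitrogen would match compound 3 or compound 2, and no measurement at hand gives a cause for the step.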